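Removing One Chlorine from a Weakly Cytotoxic Sulfonyl Urea

A few compounds are considered here, and "the series" means these few. Any claim that something is new, unique, unknown or untested is made for them only; others in the source may bear on it.

Measured so far:
- compound 1, `O=C1c2ccccc2N(COCc2ccccc2)S(=O)(=O)N1Cc1ccccc1`: 25000 nM
- compound 2, `O=C1c2ccccc2N(Cc2ccc(Cl)cc2)S(=O)(=O)N1Cc1ccc(Cl)cc1`: 35800 nM

In a functional assay on CCRF-CEM cells (Homo sapiens) for inhibition (on this read-out lower numbers stand for higher toxicity in this test and higher numbers for lower toxicity in this test), compound 2 shows the highest of the two numbers, and its nearest neighbour is compound 1, whose number lies within the usual scatter of it. Compound 3, `O=C1c2ccccc2N(Cc2ccc(Cl)cc2)S(=O)(=O)N1Cc1ccccc1`, has not yet been measured. Going from compound 2 to compound 3 means (hydrogen in place of chloro on an aromatic carbon), that is, 4-chlorobenzyl becomes benzyl on one side of the shared core. Within the data shown here, with no step between measured compounds to lean on, no change beyond the scatter is expected, so the step from compound 2 to compound 3 is estimated as a 1.2-fold lower number from compound 2 to compound 3 (0.08 log units; within the scatter). Compound 3 is therefore expected to give about 30000 nM, within 12000 nM to 75000 nM.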

Compound 3, half-maximal cytotoxic concentration: 19700 nM
The estimate for compound 3 lay 1.5-fold (0.18 log units) above the measured number, within the range that was stated.
By their numbers in this assay, from the lowest: compounds 3, 1 and 2 (each within the scatter of the next).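

In this assay, taking the chloro off one benzyl group gives a 1.8-fold lower number from compound 2 to compound 3 (0.26 log units; within the scatter) and so leaves the number unchanged for practical purposes, which means this chlorine is not needed to keep the weak cytotoxicity seen here. Swapping benzyloxy for 4-chlorophenyl on the chain carbon gives a 1.3-fold lower number from compound 1 to compound 3 (0.10 log units; within the scatter) and is just as unreadable as a change. Nothing measured here bears on why these numbers sit so close. Still open, from the compounds shown here alone, is whether an amine or a carboxylic acid in place of the chloro would move the number beyond the scatter.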